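Fluoro in place of hydrogen: compound 2 to compound 4

This account rests on a few compounds, and the source may have more. Where it says the series, first, only, none or still open, it means among the compounds named here.

Compound 2 `c1ccc(-c2n[nH]cc2N2CCNCC2)cc1` carries an unsubstituted six-membered aromatic ring of carbon only on the shared core. In an assay on isolated protein for binding affinity to 5-hydroxytryptamine receptor 3A (Homo sapiens) (on this read-out lower numbers stand for stronger inhibition and higher numbers for weaker inhibition), compound 2 returns only a limit of the assay, > 10000 nM. Compound 1 `COc1ccc(-c2n[nH]cc2N2CCNCC2)cc1`, with methoxy on that ring, also sits at a limit in this assay, > 10000 nM. Compound 3 `Clc1cccc(-c2n[nH]cc2N2CCNCC2)c1`, with chloro on the ring, gives 806 nM in this assay. The step that the two limits leave unreadable from compound 1 to compound 2 cannot be sized because of the limit of > 10000 nM in this assay, at which 2 of the 3 values shown sit. Going by the values given here, the step of an at least 12-fold lower number from compound 2 to compound 3 (1.09 log units; beyond the scatter) is the one readable change in the set, and it runs toward a lower number.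

Compound 4 `Fc1ccccc1-c1n[nH]cc1N1CCNCC1` differs from compound 2 by fluoro in place of hydrogen on an aromatic carbon. Among the compounds with values here, the chloro step is the only halogen precedent, but fluoro is a different halogen and enters ortho to a large group, so a gain smaller than an at least 12-fold lower number from compound 2 to compound 3 (1.09 log units; beyond the scatter) is expected. For compound 4 a step of an at least 2.0-fold lower number from compound 2 to compound 4 (0.30 log units; that floor lies within the scatter) is expected. Compound 4 is therefore estimated at 5000 nM, with a range from 1200 nM to 20000 nM, and a limit rather than a number remains a real possibility.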

Compound 4, inhibition constant: 1960 nM
Beside the measured number, compound 4's estimate is 2.6-fold (0.41 log units) above it; the range from low to high includes it.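

In this assay, fluoro on an aromatic carbon ortho to a large group gives an at least 5.1-fold lower number from compound 2 to compound 4 (0.70 log units; beyond the scatter). Compound 4 is thus the second compound with a halogen on the ring, after compound 3, to return a number rather than a limit, whereas compound 1 with methoxy remains at a limit. The step is only a floor, and its full size cannot be read, because compound 2 has no number of its own: the limit of > 10000 nM in this assay, at which 2 of the 4 values shown sit.

Open, going by these compounds, is whether chloro, trifluoromethyl or an amine in the same place, ortho to a large group, also returns a number, and whether fluoro elsewhere on the ring matches compound 4. Also open, on these data alone, is whether a methyl group or a longer chain on the shared core changes the value of compound 4.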